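Trifluoromethyl on the phenyl of compound 2

The compounds below may be only part of what the source reports. "The series", "measured", "known", "first", "only" and "open" are said of these compounds alone.

Measured so far in an ADME assay on BHK-21 cells (Mesocricetus auratus) for cytotoxicity, read by MTT assay; a higher number here means that more compound is tolerated, a lower number that less compound is tolerated:
- compound 1 `C/C(=N\NC(N)=S)c1ccc2[nH]c(-c3ccc(C(F)(F)F)cc3)nc2c1` with 5000 nM as its value
- compound 2 `C/C(=N\NC(N)=S)c1ccc2c(c1)nc(-c1ccccc1)n2C1CCCCC1` with 38000 nM as its value

Compound 2 holds the higher number of the two at 38000 nM, and its gap to compound 1 lies beyond the scatter. Compound 1 stands at 5000 nM on the lower side. Compound 3 `C/C(=N\NC(N)=S)c1ccc2c(c1)nc(-c1ccc(C(F)(F)F)cc1)n2C1CCCCC1`, not yet measured, carries trifluoromethyl in place of hydrogen on an aromatic carbon of compound 2 (trifluoromethyl in place of hydrogen on an aromatic carbon), so that phenyl becomes 4-(trifluoromethyl)phenyl. Within the data shown here, no measured pair isolates this change. Among the measured compounds shown here, the only guide is compound 1, which also carries 4-(trifluoromethyl)phenyl and gives 5000 nM in the lower position, so a lower number is expected. The estimated change is a 2.5-fold lower number from compound 2 to compound 3 (0.40 log units; beyond the scatter) and is expected to lie beyond the scatter, though with wide uncertainty. Compound 3 is estimated at 15000 nM with an expected range of 6000 nM to 35000 nM in this assay for now.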

Compound 3, half-maximal cytotoxic concentration: > 100000 nM
Compound 3: only a limit was reported (the forecaster's own chance of this, stated with the estimate: 10%); middle value at least 6.6-fold (0.82 log units) away from the limit.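

In this assay, the change from phenyl to 4-(trifluoromethyl)phenyl on the cyclohexyl-bearing core gives an at least 2.6-fold higher number from compound 2 to compound 3 (0.42 log units; beyond the scatter), so with cyclohexyl in place, this group para to a large group goes with more compound being tolerated. With 4-(trifluoromethyl)phenyl held constant, cyclohexyl in place of hydrogen on an aromatic nitrogen gives an at least 20-fold higher number from compound 1 to compound 3 (1.30 log units; beyond the scatter), so the low number of compound 1 does not carry over once cyclohexyl is present. Both steps rest on compound 3, which is reported only as a limit and not as a number: the limit of > 100000 nM in this assay, at which 1 of the 3 values shown sits.

As far as these compounds go, the true size of either step remains open. Also open, from the compounds shown here alone, is whether another group at this aromatic carbon, such as a methoxy group or a carboxylic acid, or an ethyl chain in place of cyclohexyl, would follow the same direction.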